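The source may report more compounds than this note shows. Statements on the series, on what has been measured and on what is new or still open speak of the compounds shown alone.

Compound 1 `Cc1cnc(N)nc1-c1ccccc1`: in a functional assay on the whole organism for inhibition, with Rattus norvegicus as the target, with stated times of 1 h and 3.5 h, at a dose of 100 mg/kg by the oral route (on this read-out higher numbers stand for more inhibition at the one dose given (going by the name of the read-out) and lower numbers for less inhibition), compound 1 gives 34%.
Compound 2 `c1cc(-c2ccncn2)ccn1`: in this assay compound 2 gives 45%.
Compound 3 `N#CNc1nccc(-c2ccncc2)n1`: in this assay compound 3 gives < 5%, which is a limit of the assay and not a number.

Compound 3 therefore stands at the floor of what this assay reports, and only a limit is known for it, as shown by the limit of < 5% in this assay, at which 1 of the 3 values shown sits. Among the compounds with values here, the one measured step that touches this position is a number at least 40 percentage points lower from compound 2 to compound 3 (beyond the scatter); it carried compound 2 down to that limit. The unmeasured compound 4 `CC(=O)Nc1nccc(-c2ccncc2)n1` differs from compound 3 in a single place: acetyl in place of cyano on a nitrogen on an aromatic ring. Within the data shown here, no measured pair shows an acetyl in place of a cyano on such a nitrogen, so the size of this step has no direct precedent. Given that compound 3 already sits at the limit, compound 4 is expected to remain low, with an estimated step of a number at least 5 percentage points higher from compound 3 to compound 4 (that floor lies within the scatter). The estimate for compound 4 in this assay is 10%, expected to fall between 0% and 30%.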

Compound 4, a percentage reported as inhibition, in the whole organism at one dose (the size of the read-out at that dose, not a potency): 52%
Compound 4: the middle estimate sits 42 percentage points below what was measured; measured number outside the range, above it.
By their numbers in this assay, from the lowest: compound 1; then compounds 2 and 4 (each within the scatter of the next). At a limit, below all of these: compound 3.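

In this assay, the group on this nitrogen decides the outcome: acetyl in place of cyano gives a number at least 47 percentage points higher from compound 3 to compound 4 (beyond the scatter), so the loss seen with cyanoamino does not extend to every group attached through this nitrogen. That step has only a lower bound, as compound 3 sits at a limit of the assay: the limit of < 5% in this assay, at which 1 of the 4 values shown sits. Acetamido in place of hydrogen on this aromatic carbon gives a number 7 percentage points higher from compound 2 to compound 4 (within the scatter), so the read-out with acetamido cannot be told apart from the one with hydrogen.

Only hydrogen, cyanoamino and acetamido are shown at this place, so it remains open how narrowly the read-out depends on the acetyl group. A longer chain such as propanoyl, or a methanesulfonyl group, on the same nitrogen would test whether the result holds beyond acetyl.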